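A few compounds are considered here, and "the series" means these few. Any claim that something is new, unique, unknown or untested is made for them only; others in the source may bear on it.

Measured so far in a functional assay on OVCAR-3 cells (Homo sapiens) for antiproliferative activity, read by MTT assay, with a stated time of 24 h; on this read-out lower numbers stand for stronger inhibition and higher numbers for weaker inhibition:
Compound 1 `O=C(NNc1ccccc1F)c1ccccc1NS(=O)(=O)c1cnc(O)nc1O`: 9570 nM
Compound 2 `O=C(NNc1ccc(F)cc1)c1ccccc1NS(=O)(=O)c1cnc(O)nc1O`: > 20000 nM

Compound 2 has no exact number: its > 20000 nM is a limit of the assay. Of the two compounds, it therefore stands at the weaker end.

Compound 3 `O=C(NNC(=O)c1ccccc1NS(=O)(=O)c1cnc(O)nc1O)c1ccccc1Cl` keeps the shared core but carries (2-chlorophenyl)carbonyl in place of 4-fluorophenyl on an amine nitrogen. Put another way, (4-fluorophenyl)amino becomes ((2-chlorophenyl)carbonyl)amino.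

Going by the values given here, only one measured step touches this nitrogen: an at least 2.0-fold higher number from compound 1 to compound 2 (0.32 log units; beyond the scatter). It shows that the read-out responds to what sits there, but it swaps one fluorophenyl for another, so it is only a loose guide to a change of this kind. Among the compounds with values here, the one exact number at this site is that of compound 1, 9570 nM, so a modest move toward stronger inhibition is expected. There is a real chance that compound 3, like compound 2, reaches the limit of the assay. The expected change is an at least 1.8-fold lower number from compound 2 to compound 3 (0.25 log units; that floor lies within the scatter). For compound 3 the estimated value is 11000 nM, with an expected range of 4000 nM to 20000 nM.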

Compound 3, half-maximal inhibitory concentration: 18200 nM
Compound 3: the middle estimate sits 1.7-fold (0.22 log units) below what was measured; measured number inside the range.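

In this assay, putting (2-chlorophenyl)carbonyl in place of 2-fluorophenyl on this amine nitrogen gives a 1.9-fold higher number from compound 1 to compound 3 (0.28 log units; within the scatter), so the two groups cannot be told apart here, even though the entering group adds a carbonyl and a hydrogen-bond acceptor. This nitrogen therefore accepts a change in the kind of group attached, not only a move of the fluorine on the ring, and still yields an exact number in this read-out. Against compound 2 the same change reads as an at least 1.0-fold lower number from compound 2 to compound 3 (0.04 log units; that floor lies within the scatter), which is only a floor and establishes no difference, since compound 2 carries only a limit: the limit of > 20000 nM in this assay, at which 1 of the 3 values shown sits.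

On these data alone, all three groups at this position carry a halogen on a phenyl ring, so it remains open whether the halogen matters at all, as a plain phenyl or a methoxyphenyl would help to show. It is also unknown whether a group of another kind on this nitrogen, such as a carboxylic acid or a longer alkyl chain, would move the number beyond the scatter in either direction.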